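This account rests on a few compounds, and the source may have more. Where it says the series, first, only, none or still open, it means among the compounds named here.

Working notes on the series. Compound 2 `OCCCc1cn(-c2ccnc3cc(Cl)ccc23)nn1` gives 151000 nM in an ADME assay on HepG2 cells (Homo sapiens) for cytotoxicity, read by MTT assay, with a stated time of 24 h (on this read-out lower numbers stand for higher toxicity in this test and higher numbers for lower toxicity in this test), the lowest of the two numbers in hand. The nearest is compound 1 `Cc1ccc(-c2cn(-c3ccnc4cc(Cl)ccc34)nn2)cc1`, which in this assay gives 352000 nM; the step of a 2.3-fold lower number from compound 1 to compound 2 (0.37 log units; beyond the scatter) is modest. Compound 3 `Clc1ccc2c(-n3cc(C4CCCCC4)nn3)ccnc2c1` gives in this assay only a limit, > 3200 nM. Owing to the limit of > 3200 nM in this assay, at which 1 of the 3 values shown sits, the steps a step that the limit leaves unreadable from compound 1 to compound 3 and a step that the limit leaves unreadable from compound 2 to compound 3 cannot be sized.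

Compound 4 `Cc1ccc(C(=O)OCCCc2cn(-c3ccnc4cc(Cl)ccc34)nn2)cc1` has not yet been measured in this assay. It differs from compound 2 by (4-methylphenyl)carbonyl in place of hydrogen on an oxygen on a saturated carbon. Among the measured compounds shown here, the only step with a readable size, a 2.3-fold lower number from compound 1 to compound 2 (0.37 log units; beyond the scatter), exchanged one group on an aromatic carbon for another and moved the number only modestly. For the measured compounds named here, the change to compound 4 has no direct parallel among the measured pairs: it keeps the three-carbon chain of compound 2 and caps its oxygen, and no measured step shows what such a capping does in this assay. Compound 4 is therefore expected to sit close to compound 2, with at most a modest step of a 1.3-fold lower number from compound 2 to compound 4 (0.10 log units; within the scatter), direction uncertain. Compound 4 is estimated at 120000 nM, with a range from 40000 nM to 350000 nM.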

Compound 4, half-maximal cytotoxic concentration: > 2460000 nM
Compound 4 gave a limit, no number; the forecaster's own chance of this, stated with the estimate: 10%; middle value at least 20-fold (1.31 log units) away from the limit.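

Capping the oxygen gives the first large step in the series: with (4-methylphenyl)carbonyl in place of hydrogen on an oxygen on a saturated carbon, this assay shows an at least 16-fold higher number from compound 2 to compound 4 (1.21 log units; beyond the scatter). This change to the hydroxyl end of the three-carbon chain therefore moves the read-out towards lower toxicity in this test, further than the exchange on the aromatic carbon did, which gave a 2.3-fold lower number from compound 1 to compound 2 (0.37 log units; beyond the scatter). The size of the new step is bounded on one side only, as the result for compound 4 is a limit and not a number: the limit of > 2460000 nM in this assay, at which 1 of the 4 values shown sits.

The compounds shown do not separate the contribution of the carbonyl from that of the 4-methylphenyl group, and a small acetyl cap, a methyl ether on the same oxygen or an amine in place of the hydroxyl would each test a different part of this change. The steps to compound 3 cannot be read, so the cyclohexyl group remains unplaced against the other groups on the aromatic carbon: the limit of > 3200 nM in this assay, at which 1 of the 4 values shown sits.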